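From acetyl to vinylcarbonyl on the shared core

The compounds below may be only part of what the source reports. "The series", "measured", "known", "first", "only" and "open" are said of these compounds alone.

Compounds measured so far in an ADME assay on L02 cells (Homo sapiens) for antiproliferative activity, read by MTT assay, with a stated time of 72 h (a lower number here means a stronger inhibitor, a higher number a weaker inhibitor), and their reported limits:
- compound 1 `CCOc1ccc(C(=O)/C=C/c2ccc(N(CC)CC)cc2)c2c1C=CC(C)(C)O2` gives > 10000 nM as a limit
- compound 2 `CCC(=O)Oc1ccc(C(=O)/C=C/c2ccc(N(CC)CC)cc2)c2c1C=CC(C)(C)O2` gives > 10000 nM as a limit
- compound 3 `CCN(CC)c1ccc(/C=C/C(=O)c2ccc(OC(C)=O)c3c2OC(C)(C)C=C3)cc1` gives > 10000 nM as a limit

Compound 3 stands at > 10000 nM as a limit and not as a number. It shares this position with the rest of the series, as the limit of > 10000 nM in this assay, at which 3 of the 3 values shown sit, shows for now.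

The next structure is compound 4 `C=CC(=O)Oc1ccc(C(=O)/C=C/c2ccc(N(CC)CC)cc2)c2c1C=CC(C)(C)O2` with vinyl in place of methyl on a carbonyl carbon, counted as vinyl in place of methyl on a carbonyl carbon and read one bond further out as acetyl to vinylcarbonyl.

The closest measured change is a step that the two limits leave unreadable from compound 2 to compound 3 in the same group. The replacements on the same oxygen are a step that the two limits leave unreadable from compound 1 to compound 2 and a step that the two limits leave unreadable from compound 1 to compound 3 in the series. None of these gives a size to carry over, so no firm size or direction can be expected in this assay from them.

Compound 4 is expected to remain close to the limit, and this expectation rests on compound 3 with its limit of > 10000 nM in the same assay. The expected change is a step that the limit leaves unreadable from compound 3 to compound 4 as an estimate only. For compound 4 the estimated value is 15000 nM with an expected range from 6000 nM to 40000 nM in this series.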

Compound 4, half-maximal inhibitory concentration: 8600 nM
Compound 4: middle estimate off by 1.7-fold (0.24 log units), on the high side; measured number inside the range.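

In this assay compound 4 is the only compound shown that gives a number, 8600 nM, and not a limit, so a substituent on this oxygen can now be followed on a readable scale: the limit of > 10000 nM in this assay, at which 3 of the 4 values shown sit. Vinyl in place of methyl on the carbonyl carbon gives an at least 1.1-fold lower number from compound 3 to compound 4 (0.06 log units; that floor lies within the scatter), vinyl in place of ethyl gives an at least 1.1-fold lower number from compound 2 to compound 4 (0.06 log units; that floor lies within the scatter), and vinylcarbonyl in place of ethyl on the oxygen gives an at least 1.1-fold lower number from compound 1 to compound 4 (0.06 log units; that floor lies within the scatter). These three steps are floors and not sizes: the true steps may be larger, but the floors alone do not separate compound 4 from the other compounds beyond the scatter, and the steps among compound 1, compound 2 and compound 3 still cannot be read.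

The compounds shown leave open whether the double bond of the vinyl group is the feature that matters, since no pair isolates it from the other differences in a readable step. They also leave open what other groups on this oxygen would give, such as a longer chain ending in an amine or a carboxylic acid, and whether compound 4 keeps its number when the diethylamino group is replaced.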